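The source may report more compounds than this note shows. Statements on the series, on what has been measured and on what is new or still open speak of the compounds shown alone.

In a functional assay on SGC-7901 cells (Homo sapiens) for cytotoxicity, read by MTT assay, with a stated time of 72 h (on this read-out higher numbers stand for weaker inhibition and lower numbers for stronger inhibition), compound 1 (`CC(C)(C)NC(=S)N/N=C1\CC(c2ccc(O)cc2)Oc2cc(O)ccc21`) gives 31000 nM and compound 2 (`CCCN(CCC)C(=S)N/N=C1\CC(c2ccc(O)cc2)Oc2cc(O)ccc21`) gives 32200 nM. For the measured compounds named here, compound 2 therefore stands level with compound 1, and the only measured step, a 1.0-fold higher number from compound 1 to compound 2 (0.02 log units; within the scatter), lies within the scatter. Next in the series is compound 3 (`Oc1ccc(C2C/C(=N\NC(=S)N3CCCCC3)c3ccc(O)cc3O2)cc1`), with piperidin-1-yl in place of dipropylamino on a thiocarbonyl carbon. Going by the values given here, the measured step exchanges a group at the same place and is the only evidence that bears on this change. Among the compounds with values here, no compound with a ring in this group has yet been measured, so the evidence is thin. Within the data shown here, with only that step to go on, no shift beyond the scatter is expected in this assay, and no direction can be assigned. The expected change is a 1.1-fold lower number from compound 2 to compound 3 (0.05 log units; within the scatter). For compound 3 the estimated value is 29000 nM, with an expected range of 13000 nM to 58000 nM.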

Compound 3, half-maximal inhibitory concentration: 40000 nM
The estimate for compound 3 lay 1.4-fold (0.14 log units) below the measured number, and the stated range covers the measured number.
By their numbers in this assay, from the lowest: compounds 1, 2 and 3 (each within the scatter of the next).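

In this assay, the ring of piperidin-1-yl on the thiocarbonyl carbon does not separate compound 3 from the open-chain groups (a 1.2-fold higher number from compound 2 to compound 3 (0.09 log units; within the scatter); a 1.3-fold higher number from compound 1 to compound 3 (0.11 log units; within the scatter)). This position therefore now holds three different groups, one of them cyclic, and every step among compounds 1, 2 and 3 lies within the scatter, so neither the ring nor the swap from dipropylamino to piperidin-1-yl has a readable effect here. No measurement available offers an explanation for this flat result.

On these data alone, whether morpholin-4-yl, a piperazine or an aromatic group such as anilino at this place would move the number beyond the scatter stays open. The compounds shown also say nothing about how changes to the hydroxyl groups on the shared core would affect the read-out.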